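The source may hold more compounds than are shown below. What is called first, only, known or untested is meant among the compounds shown, and "the series" means these compounds.

Compound 3 `Fc1ccccc1Nc1nc(-c2ccccc2)cs1` stands highest of the two numbers in an ADME assay on microsomes from liver (Mus musculus) for metabolic stability, read by LC-MS, using NADPH (on this read-out lower numbers stand for a shorter-lived compound and higher numbers for a longer-lived compound), where compound 3 gives 0.0483 h. Compound 2 `Cc1cccnc1Nc1ncc(-c2ccccn2)o1` gives 0.0233 h in this assay. Compound 1 `Fc1ccccc1Nc1nc(-c2ccccn2)cs1` sits at a limit of this assay, < 0.0167 h, and not at a number (the limit of < 0.0167 h in this assay, at which 1 of the 3 values shown sits). Among the measured compounds shown here, the one measured step, an at least 2.8-fold higher number from compound 1 to compound 3 (0.46 log units; beyond the scatter), touches a different part of the molecule from the one now in question. Compound 4 `Fc1cccc(-c2csc(Nc3ccccc3F)n2)c1` differs from compound 3 by fluoro in place of hydrogen on an aromatic carbon. For the measured compounds named here, no measured step bears on this change, so for compound 4 the estimated step is a 1.0-fold lower number from compound 3 to compound 4 (0.00 log units; within the scatter), with no movement beyond the scatter expected. Compound 4 is therefore expected to give about 0.048 h in this assay, with a range from 0.024 h to 0.096 h.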

Compound 4, half-life: 0.19 h
Estimate against measurement, compound 4: 4.0-fold (0.60 log units) below; measured number above the stated range.
By their numbers in this assay, from the lowest: compound 2; then compound 3; then compound 4. At a limit, below all of these: compound 1.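

Fluoro in place of hydrogen on an aromatic carbon of the six-membered aromatic ring of carbon only, meta to a large group, gives a 3.9-fold higher number from compound 3 to compound 4 (0.59 log units; beyond the scatter) in this assay, the first read on this position in the series. This place on the ring is therefore not silent for half-life, and a single fluoro is enough to move the number beyond the scatter. As far as these compounds go, whether chloro, methoxy or an amine at this place moves the half-life in the same direction stays open, as does the effect of fluoro on the other carbons of this ring. Nothing shown bears on why the half-life rises with this change.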